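The compounds below may be only part of what the source reports. "The series", "measured", "known", "first", "only" and "open" are said of these compounds alone.

Compound 2 `C=C1CC[C@@H]2[C@](C)(COC(C)=O)[C@H](OC(C)=O)CC[C@@]2(C)[C@H]1CC(Nc1ccc(S(=O)(=O)Nc2cc(C)on2)cc1)C1=CCOC1=O` is one of two close relatives measured in a functional assay on PC-3 cells (Homo sapiens) for inhibition, read by sulforhodamine B assay, with a stated time of 48 h; a higher number here means a weaker inhibitor of growth, a lower number a stronger inhibitor of growth; in that test compound 2 gives 4310 nM, while compound 1 `C=C1CC[C@@H]2[C@](C)(COC(C)=O)[C@H](OC(C)=O)CC[C@@]2(C)[C@H]1CC(Nc1ccc(S(=O)(=O)Nc2ccc(Cl)nn2)cc1)C1=CCOC1=O` gives 5250 nM, and the two values lie within the usual scatter of each other, so neither stands apart. Among the compounds with values here, the only measured step, a 1.2-fold lower number from compound 1 to compound 2 (0.09 log units; within the scatter), replaced one small aromatic ring on the sulfonamide nitrogen with another and moved nothing beyond the scatter. Compound 3 `C=C1CC[C@@H]2[C@](C)(COC(C)=O)[C@H](OC(C)=O)CC[C@@]2(C)[C@H]1CC(Nc1ccc(S(=O)(=O)Nc2nccc(C)n2)cc1)C1=CCOC1=O` makes a similar exchange: 4-methylpyrimidin-2-yl in place of 5-methyl-1,2-oxazol-3-yl on a sulfonamide nitrogen. Because that earlier swap read a 1.2-fold lower number from compound 1 to compound 2 (0.09 log units; within the scatter), compound 3 is expected to stay close, estimated at 4500 nM, between 2000 nM and 10000 nM. The expected step is a 1.0-fold higher number from compound 2 to compound 3 (0.02 log units; within the scatter), nothing beyond the scatter.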

Compound 3, concentration for total growth inhibition: 15700 nM
Compound 3: the middle estimate sits 3.5-fold (0.54 log units) below what was measured; measured number above the stated range.
By their numbers in this assay, from the lowest: compounds 2 and 1 (each within the scatter of the next); then compound 3.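

In this assay the ring on the sulfonamide nitrogen turns out to matter: 4-methylpyrimidin-2-yl brings a 3.6-fold higher number from compound 2 to compound 3 (0.56 log units; beyond the scatter) and a 3.0-fold higher number from compound 1 to compound 3 (0.48 log units; beyond the scatter), while 5-methyl-1,2-oxazol-3-yl and 6-chloropyridazin-3-yl could not be told apart. This position therefore responds to the ring placed on it, and here the exchange gives a weaker inhibitor of growth. No measurement here accounts for this loss.

Still open, on these data alone, is how a plain phenyl ring on that nitrogen would read. An unsubstituted pyrimidin-2-yl would show whether the methyl group plays any part.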